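Homologating the diacid on a triazole-linked prodrug

A few compounds are considered here, and "the series" means these few. Any claim that something is new, unique, unknown or untested is made for them only; others in the source may bear on it.

Measured compounds:
compound 1, `CC(C)(C)c1[nH]cnc1/C=c1\[nH]c(=O)/c(=C/c2ccccc2)nc1OCOC(=O)CCCc1cn([C@@H]2O[C@H](CO)[C@H](O)[C@H](O)[C@H]2O)nn1`: 7.5 ug/mL
compound 2, `CC(C)(C)c1[nH]cnc1/C=c1\[nH]c(=O)/c(=C/c2ccccc2)nc1OCOC(=O)CCCc1cn([C@@H](CC(=O)O)C(=O)O)nn1`: > 100000 ug/mL

In a physicochemical assay for solubility, read by HPLC, with a stated time of 15 min (on this read-out lower numbers stand for lower solubility and higher numbers for higher solubility), compound 1 gives 7.5 ug/mL. Compound 2 gives > 100000 ug/mL, which is a limit of the assay and not a number. The step of an at least 13000-fold higher number from compound 1 to compound 2 (4.12 log units; beyond the scatter) therefore has no fixed size; only the limit of > 100000 ug/mL in this assay, at which 1 of the 2 values shown sits, bounds it. Compound 2 thus stands at the top of what this assay can report.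

Compound 3, `CC(C)(C)c1[nH]cnc1/C=c1\[nH]c(=O)/c(=C/c2ccccc2)nc1OCOC(=O)CCCc1cn([C@@H](CCC(=O)O)C(=O)O)nn1`, differs from compound 2 by carboxymethyl in place of carboxy on a saturated chain carbon, two bonds along the chain from an aromatic nitrogen and a carbonyl carbon. For the measured compounds named here, the one measured step, from compound 1 to compound 2, concerns a different exchange on the aromatic nitrogen and does not bear on this change; no measured step does. Lacking such evidence, compound 3 is expected to show no step beyond the scatter, a number no higher from compound 2 to compound 3 (the limit leaves the size open), and likely to sit at the limit again. Compound 3 is estimated at 100000 ug/mL, between 30000 ug/mL and 200000 ug/mL.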

Compound 3, solubility: > 100000 ug/mL
Compound 3 ended at the assay's limit (the forecaster's own chance of this, stated with the estimate: 80%); the middle value sits exactly at the limit.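

Replacing 3,4,5-trihydroxy-6-(hydroxymethyl)oxan-2-yl on the aromatic nitrogen with 1,3-dicarboxypropyl gives an at least 13000-fold higher number from compound 1 to compound 3 (4.12 log units; beyond the scatter) in this assay, so the large step is not confined to 1,2-dicarboxyethyl. Carboxymethyl in place of carboxy on this saturated chain carbon leaves the read-out at a limit, where compound 2 also stood, and the step between these two compounds cannot be read. Anything said about this change is therefore bounded only by the assay: the limit of > 100000 ug/mL in this assay, at which 2 of the 3 values shown sit.

Going by these compounds, how far past the limit either compound 2 or compound 3 lies stays open. So does whether a longer chain ending in a carboxylic acid, or an amine on this saturated chain carbon, would stay at this limit or fall back towards compound 1.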